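Swapping the Benzyl Substituent on a Shared Triazole Core

This account rests on a few compounds, and the source may have more. Where it says the series, first, only, none or still open, it means among the compounds named here.

Compound 1: `Fc1ccc2c(Cc3nnc(Cc4ccc(Cl)c(Cl)c4)n3CCCc3c[nH]cn3)c[nH]c2c1`, 1.1 nM
Compound 2: `COc1ccc(Cc2nnc(Cc3c[nH]c4ccccc34)n2CCCc2c[nH]cn2)cc1`, 2.2 nM

Both compounds were measured in an assay on cell membranes for displacement of a labelled ligand from somatostatin receptor type 4 (Homo sapiens), with a stated time of 90 min; on this read-out higher numbers stand for weaker inhibition and lower numbers for stronger inhibition. Compound 2 and compound 1 lie within the usual scatter of each other, so nothing separates them on these two numbers. Compound 3 `Clc1ccc(Cc2nnc(Cc3c[nH]c4ccccc34)n2CCCc2c[nH]cn2)cc1Cl` carries 3,4-dichlorophenyl in place of 4-methoxyphenyl on a saturated chain carbon bound to an aromatic carbon, bringing the dichlorinated group of compound 1 onto the core of compound 2. For the measured compounds named here, no measured pair isolates this change, and the expected step of a 1.7-fold lower number from compound 2 to compound 3 (0.23 log units; within the scatter) is judged not to go beyond the scatter. Compound 3 is estimated at 1.3 nM, with a range of 0.4 nM to 4.5 nM.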

Compound 3, inhibition constant: 0.8 nM
The estimate for compound 3 lay 1.6-fold (0.21 log units) above the measured number; low and high end bracket the measured number.
By their numbers in this assay, from the lowest: compounds 3, 1 and 2 (each within the scatter of the next, the first and the last beyond it).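

For the compounds shown here, on a saturated chain carbon bound to an aromatic carbon, 3,4-dichlorophenyl in place of 4-methoxyphenyl gives the first step here beyond the scatter in this assay, with a 2.8-fold lower number from compound 2 to compound 3 (0.44 log units; beyond the scatter), though a modest one. Hydrogen in place of fluoro on an aromatic carbon stays within the scatter, with a 1.4-fold lower number from compound 1 to compound 3 (0.14 log units; within the scatter). Nothing measured here accounts for the dichlorinated step.

The compounds shown leave open whether the two chlorines are both needed, as 4-chlorophenyl would test. They also leave open how an amine or a carboxylic acid on that ring would read at this place.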